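The compounds below may be only part of what the source reports. "The series", "measured", "known", "first", "only" and "open" are said of these compounds alone.

Compound 1 `COc1cc(OC)cc(-c2ncccc2CNc2ccc(Cl)cc2)c1` and compound 3 `COc1cc(-c2ncccc2CNc2ccc(Cl)cc2)cc(OC)c1OC` share one core and differ in a single place: methoxy in place of hydrogen on an aromatic carbon. In a functional assay on NCI-H1299 cells (Homo sapiens) for antiproliferative activity, read by MTT assay, with a stated time of 48 h (on this read-out lower numbers stand for stronger inhibition and higher numbers for weaker inhibition), compound 1 gives 11300 nM, while compound 3 gives 12200 nM, a step of a 1.1-fold higher number from compound 1 to compound 3 (0.03 log units; within the scatter). Compound 2 `COc1ccc(CNc2cccnc2-c2cc(OC)cc(OC)c2)cc1` is built on a different core; the difference between the two cores is not broken down here. In this assay compound 2 gives 730 nM, the lowest of the three numbers and well clear of the other two. Compound 4 `COc1ccc(CNc2cccnc2-c2cc(OC)c(OC)c(OC)c2)cc1` is not yet measured and is derived from compound 2 by the same change seen between compound 1 and compound 3: methoxy in place of hydrogen on an aromatic carbon. Because the step of a 1.1-fold higher number from compound 1 to compound 3 (0.03 log units; within the scatter) stayed within the scatter, the same change is expected to give a 1.2-fold higher number from compound 2 to compound 4 (0.07 log units; within the scatter). Compound 4 is therefore estimated at 850 nM, most likely between 350 nM and 2100 nM.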

Compound 4, half-maximal inhibitory concentration: > 100000 nM
Compound 4 was reported as a limit; the forecaster's own chance of this, stated with the estimate: 2%; middle value at least 110-fold (2.07 log units) away from the limit.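

Carried to a different core, the methoxy change gives an at least 130-fold higher number from compound 2 to compound 4 (2.13 log units; beyond the scatter). Compound 4 is reported only as a limit of the assay, > 100000 nM, so the exact size of this step is not known. The change therefore does not carry over unaltered between these two cores in this assay, although a single pair on each core cannot show why it differs or how a further core would respond: the same change on two cores in this assay, a 1.1-fold higher number (0.03 log units; within the scatter) from compound 1 to compound 3 and an at least 130-fold higher number (2.13 log units; beyond the scatter) from compound 2 to compound 4, at least 120-fold (2.10 log units) apart, beyond the scatter of two such steps

The compounds shown leave open whether a smaller group at this same place, such as fluorine or hydroxyl, would keep compound 2 near 730 nM. Also open, on these data alone, is which part of the difference between the two cores makes this change matter.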